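The source may hold more compounds than are shown below. What is called first, only, known or untested is meant among the compounds shown, and "the series" means these compounds.

Measured compounds in an assay on CHO cells for displacement of a labelled ligand from adenosine receptor A1 (Homo sapiens), read by scintillation counting, tested at 10 uM; on this read-out lower numbers stand for less inhibition and higher numbers for more inhibition at the one concentration tested (going by the name of the read-out):

- compound 1, `Cc1csc(N)c1C(=O)c1ccc(Cl)cc1`: 1%
- compound 2, `CC(C)Cc1csc(N)c1C(=O)c1ccc(Cl)cc1`: 1%
- compound 3, `CC(C)(C)Cc1c(-c2ccncc2)sc(N)c1C(=O)c1ccc(Cl)cc1`: 1%

Compound 3 stands level with both others at the digits shown; in this assay compound 3 gives 1%, compound 1 gives 1% and compound 2 gives 1%, all within the scatter of one another. For the measured compounds named here, the only single-point step measured so far, no change at the digits printed from compound 1 to compound 2 (within the scatter), concerns a saturated chain carbon and not the ring carbon that is varied here, so no measured step bears directly on the present change. Compound 4, `CC(C)(C)Cc1c(-c2cc(F)ccc2F)sc(N)c1C(=O)c1ccc(Cl)cc1`, differs from compound 3 in one place: 2,5-difluorophenyl in place of pyridin-4-yl on an aromatic carbon. Going by the values given here, since compound 3 and its two neighbours all sit at the same low level, and the one measured step showed no change, a step of no size beyond the scatter is expected from compound 3 to compound 4, a number 1 percentage points higher from compound 3 to compound 4 (within the scatter). Compound 4 is therefore estimated to give 2% in this assay, in the range -5% to 12%.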

Compound 4, a percentage reported as inhibition, at one concentration (the size of the read-out at that concentration, not a potency): 3%
Estimate against measurement, compound 4: 1 percentage points below; the measured number falls inside the stated range.
By their numbers in this assay, from the lowest: compounds 1, 2, 3 and 4 (each within the scatter of the next).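

In this assay, the exchange of pyridin-4-yl for 2,5-difluorophenyl on the aromatic carbon next to the ring sulfur comes to a number 2 percentage points higher from compound 3 to compound 4 (within the scatter) and is the first step shown at this position, the earlier step having concerned a saturated chain carbon. With the neopentyl group kept in place, a ring of carbon only with no hydrogen-bond acceptor and a ring with one hetero atom and a hydrogen-bond acceptor read alike, and neither group takes the compound off the low level. No measurement at hand bears on the reason for this.

The compounds shown leave open whether another group at this position, such as a carboxylic acid or an aliphatic amine, would behave the same way. They also leave open what a longer chain in place of the neopentyl group would do.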